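The source may hold more compounds than are shown below. What is called first, only, known or untested is meant among the compounds shown, and "the series" means these compounds.

Working notes on the carbamate series in a functional assay on the whole organism for inhibition, with Mus musculus as the target, in the writhing test, with a stated time of 1 h, at a dose of 10 mg/kg by the oral route; on this read-out lower numbers stand for less inhibition and higher numbers for more inhibition at the one dose given (going by the name of the read-out). Compound 1 `NC(=O)OC(CCN1CCN(c2ccc(C(F)(F)F)cc2[N+](=O)[O-])CC1)c1ccccc1` gives 50%; compound 2 `COc1ccc(N2CCN(CCC(OC(N)=O)c3ccc(Cl)c(Cl)c3)CC2)cc1` gives 61%; compound 3 `NC(=O)OC(CCN1CCN(c2ccccc2)CC1)c1ccc([N+](=O)[O-])cc1` gives 91.2%. Compound 2 stands second of the three numbers, with compound 1 lower and compound 3 higher, both gaps beyond the scatter. Compound 4 `COc1ccc(N2CCN(CCC(OC(N)=O)c3ccc(C)cc3C)CC2)cc1` is not yet measured; it differs from compound 2 by 2,4-dimethylphenyl in place of 3,4-dichlorophenyl on a saturated chain carbon bound to an oxygen next to a carbonyl group and a saturated chain carbon. Among the measured compounds shown here, no measured pair in this set isolates such an exchange, so the size of the step is uncertain. A modest move is expected, and the step from compound 2 to compound 4 in this assay is estimated as a number 6 percentage points lower from compound 2 to compound 4 (within the scatter). For compound 4 the expected value is 55%, within a range of 35% to 75%.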

Compound 4, a percentage reported as inhibition, in the whole organism at one dose (the size of the read-out at that dose, not a potency): 62%
The estimate for compound 4 lay 7 percentage points below the measured number; the range from low to high includes it.
By their numbers in this assay, from the lowest: compound 1; then compounds 2 and 4 (each within the scatter of the next); then compound 3.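

In this assay, among the compounds shown here, 2,4-dimethylphenyl in place of 3,4-dichlorophenyl gives a number 1 percentage points higher from compound 2 to compound 4 (within the scatter), the first single-place step. At this saturated chain carbon, then, the two chlorine atoms can give way to two methyl groups in a different arrangement with no change beyond the scatter at the one dose given. No measurement at hand bears on why the two groups read alike. Open, from the compounds shown here alone, is whether a phenyl carrying an amine or a carboxylic acid would hold the read-out at this place, and whether the same exchange would read alike on the core of compound 1 or compound 3.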